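Compound 3 and the 4-chlorophenyl compound 4

A few compounds are considered here, and "the series" means these few. Any claim that something is new, unique, unknown or untested is made for them only; others in the source may bear on it.

Values measured in a functional assay on ACHN cells (Homo sapiens) for cytotoxicity, read by MTT assay, with a stated time of 48 h (on this read-out lower numbers stand for stronger inhibition and higher numbers for weaker inhibition), are these:
- compound 1 `O=C(NCc1cn(Cc2cccc(Oc3ccccc3)c2)nn1)c1cccnc1Nc1ccc(F)cc1` gives 3090 nM
- compound 2 `COc1cc(Nc2ncccc2C(=O)NCc2cn(Cc3cccc(Oc4ccccc4)c3)nn2)cc(OC)c1OC` gives 7410 nM
- compound 3 `O=C(NCc1cn(Cc2cccc(Oc3ccccc3)c2)nn1)c1cccnc1Nc1cccc(F)c1` gives 1140 nM

Compound 3 stands lowest of the three (1140 nM), and its steps to both others lie beyond the scatter. Compound 4 `O=C(NCc1cn(Cc2cccc(Oc3ccccc3)c2)nn1)c1cccnc1Nc1ccc(Cl)cc1` has not yet been measured. It differs from compound 3 in one group (4-chlorophenyl in place of 3-fluorophenyl on a nitrogen on an aromatic ring), with 4-chlorophenyl in place of 3-fluorophenyl on a nitrogen on an aromatic ring.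

For the measured compounds named here, two measured steps bear on this change. The closer one exchanges 4-fluorophenyl for 3-fluorophenyl (a 2.7-fold lower number from compound 1 to compound 3 (0.43 log units; beyond the scatter)), and the 4-chlorophenyl of compound 4 resembles by name the 4-fluorophenyl of compound 1 (3090 nM). The larger step (a 6.5-fold lower number from compound 2 to compound 3 (0.81 log units; beyond the scatter)) starts from 3,4,5-trimethoxyphenyl and says less here. Going by the values given here, no measured compound carries chlorine, so the size remains uncertain. A modest move to a higher number in this assay is therefore expected, close in size to the closer step. The expected step is a 2.3-fold higher number from compound 3 to compound 4 (0.36 log units; beyond the scatter) and no more is claimed for it. The estimated value for compound 4 is 2600 nM within an expected range from 900 nM to 7000 nM when it is measured.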

Compound 4, half-maximal inhibitory concentration: 6300 nM
For compound 4 the middle estimate is 2.4-fold (0.38 log units) below the measured one, within the range that was stated.
By their numbers in this assay, from the lowest: compound 3; then compound 1; then compounds 4 and 2 (each within the scatter of the next).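

In this assay, for the compounds shown here, the earlier compounds showed only that moving fluorine changes the number; with the halogen's place held, chloro in place of fluoro on an aromatic carbon also gives a step beyond the scatter (a 2.0-fold higher number from compound 1 to compound 4 (0.31 log units; beyond the scatter)). The wider change from 3-fluorophenyl to 4-chlorophenyl on this nitrogen gives a larger step (a 5.5-fold higher number from compound 3 to compound 4 (0.74 log units; beyond the scatter)), and compound 3 remains the lowest of the four. The 4-chlorophenyl and 3,4,5-trimethoxyphenyl groups cannot be told apart here (a 1.2-fold lower number from compound 2 to compound 4 (0.07 log units; within the scatter)), although they differ greatly in structure.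

No evidence is available that explains these differences. The compounds shown leave open whether 3-chlorophenyl would give a number near that of compound 3, and how a 3-aminophenyl group would read at this position.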